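Chloro to Bromo: One Step Measured, One Expected

A few compounds are considered here, and "the series" means these few. Any claim that something is new, unique, unknown or untested is made for them only; others in the source may bear on it.

Two pairs of compounds share a common core and differ only in a single halogen. Compound 1 `O=C1C(=O)N(CN2CCN(c3ccnc4cc(C(F)(F)F)ccc34)CC2)c2cc(Cl)ccc21` carries a chloro group, while compound 2 `O=C1C(=O)N(CN2CCN(c3ccnc4cc(C(F)(F)F)ccc34)CC2)c2cc(Br)ccc21` carries a bromo group in the same place. In a functional assay on MDA-MB-468 cells (Homo sapiens) for cytotoxicity, read by sulforhodamine B assay, with a stated time of 48 h (a lower number here means a stronger inhibitor of growth, a higher number a weaker inhibitor of growth), compound 1 gives 26100 nM and compound 2 gives 24800 nM; the change bromo in place of chloro on an aromatic carbon amounts to a 1.1-fold lower number from compound 1 to compound 2 (0.02 log units; within the scatter), so the two numbers cannot be told apart.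

Compound 3 `NC(=S)N/N=C1/C(=O)N(CN2CCN(c3ccnc4cc(C(F)(F)F)ccc34)CC2)c2cc(Cl)ccc21` has a different core; how it differs from the core of compound 1 is not broken down here. In this assay compound 3 gives 11000 nM, the lowest of the three numbers, and its gap to compound 1 and to compound 2 lies beyond the usual scatter.

Compound 4 `NC(=S)N/N=C1/C(=O)N(CN2CCN(c3ccnc4cc(C(F)(F)F)ccc34)CC2)c2cc(Br)ccc21` is not yet measured and stands to compound 3 as compound 2 stands to compound 1: the change is bromo in place of chloro on an aromatic carbon, the same change at the same place. Because the earlier step was a 1.1-fold lower number from compound 1 to compound 2 (0.02 log units; within the scatter), the expected step is a 1.1-fold lower number from compound 3 to compound 4 (0.04 log units; within the scatter). Compound 4 is therefore estimated at 10000 nM, with the expected range running from 5000 nM to 22000 nM.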

Compound 4, concentration for 50% growth inhibition: 39600 nM
The estimate for compound 4 lay 4.0-fold (0.60 log units) below the measured number; the whole stated range lies below it.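

In this assay, bromo in place of chloro on an aromatic carbon does not act alike on the two cores: the same change on two cores in this assay, a 1.1-fold lower number (0.02 log units; within the scatter) from compound 1 to compound 2 and a 3.6-fold higher number (0.56 log units; beyond the scatter) from compound 3 to compound 4, 3.8-fold (0.58 log units) apart, beyond the scatter of two such steps. On the core of compound 3 the change gives a 3.6-fold higher number from compound 3 to compound 4 (0.56 log units; beyond the scatter), so a swap that left no visible mark on the core of compound 1 makes for a weaker inhibitor of growth here, and the step read on one core could not simply be carried over to the other. This does not show why the two cores part ways, and two pairs of compounds set no rule for any other core or any other change.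

The compounds shown leave open how an iodo group, a methoxy group or an amine in the place of the halogen would fare on each core. They also leave open whether such groups would show the same split between the two cores or a different one.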